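A few compounds are considered here, and "the series" means these few. Any claim that something is new, unique, unknown or untested is made for them only; others in the source may bear on it.

Working notes on the series. Compound 2 `CCC(C)NC(=O)c1nc(-c2cccs2)[nH]c(=O)c1O` carries a sec-butyl group on the amide nitrogen, and in an assay on isolated protein for inhibition of Flap endonuclease 1 (Homo sapiens) (on this read-out lower numbers stand for stronger inhibition and higher numbers for weaker inhibition), compound 2 gives 1300 nM, the lowest of the two numbers recorded so far. Within the data shown here, its neighbour is compound 1 `CCCNC(=O)c1nc(-c2cccs2)[nH]c(=O)c1O`, the propyl analogue, which in this assay gives 4200 nM; the one measured step, a 3.2-fold lower number from compound 1 to compound 2 (0.51 log units; beyond the scatter), is beyond the scatter.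

Compound 3 `CC(=O)NCCNC(=O)c1nc(-c2cccs2)[nH]c(=O)c1O` has not yet been measured. The change is 2-acetamidoethyl in place of sec-butyl on an amide-type nitrogen. Among the measured compounds shown here, no measured step concerns an acetamido-bearing chain, so the only guidance is the single step of a 3.2-fold lower number from compound 1 to compound 2 (0.51 log units; beyond the scatter), which shows that the chain on the amide nitrogen moves the numbers by a modest amount. Since that step ran from an unbranched chain to a branched one and compound 3 returns to an unbranched chain, the expectation is a rise back toward or past the number of compound 1. For compound 3 the expected step is a 3.8-fold higher number from compound 2 to compound 3 (0.59 log units; beyond the scatter), giving an estimated 5000 nM, in the range 1500 nM to 16000 nM.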

Compound 3, half-maximal inhibitory concentration: 5000 nM
Estimate against measurement, compound 3: no gap at the digits printed; the measured number falls inside the stated range.
By their numbers in this assay, from the lowest: compound 2; then compounds 1 and 3 (each within the scatter of the next).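

In this assay, 2-acetamidoethyl in place of sec-butyl gives a 3.8-fold higher number from compound 2 to compound 3 (0.59 log units; beyond the scatter) and so does not keep the lower number seen with the branched chain, although the entering group brings a hydrogen-bond donor and a hydrogen-bond acceptor absent from sec-butyl. Acetamido in place of methyl gives a 1.2-fold higher number from compound 1 to compound 3 (0.08 log units; within the scatter) and so does not separate these two unbranched chains on this read-out. Of the three chains, only sec-butyl stands apart, and no supporting data bear on the reason for this.

Open, from the compounds shown here alone, is whether a branched chain carrying an acetamido group would keep the number of compound 2. Also open, going by these compounds, is how a longer branched chain, or an unbranched chain ending in an amine or a carboxylic acid, would read at this amide-type nitrogen.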